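Turning the Enone Linker Around in Compound 1

This account rests on a few compounds, and the source may have more. Where it says the series, first, only, none or still open, it means among the compounds named here.

Three close relatives have been tested in a functional assay on MDA-MB-231 cells (Homo sapiens) for antiproliferative activity, read by MTT assay, with a stated time of 24 h; a lower number here means a stronger inhibitor, a higher number a weaker inhibitor. Compound 1 `COc1cc(-c2cc(C(=O)/C=C/c3ccc(Cl)cc3)nc3cc(-c4ccccc4)nn23)cc(OC)c1OC` gives 21600 nM, the lowest of the three numbers, though its neighbours sit within the scatter: compound 2 `COc1ccc(-c2cc(C(=O)/C=C/c3ccc(Cl)cc3)nc3cc(-c4ccccc4)nn23)cc1OC` gives 23700 nM and compound 3 `COc1ccc(-c2cc(C(=O)/C=C/c3ccc(C)cc3)nc3cc(-c4ccccc4)nn23)cc1OC` gives 22600 nM. The step of a 1.1-fold higher number from compound 1 to compound 2 (0.04 log units; within the scatter) and the step of a 1.0-fold lower number from compound 2 to compound 3 (0.02 log units; within the scatter) both stay within the scatter, so these three compounds cannot be told apart on the numbers shown.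

Compound 4 `COc1cc(-c2cc(/C=C/C(=O)c3ccccc3)nc3cc(-c4ccccc4)nn23)cc(OC)c1OC` makes a different kind of change: 2-benzoylethenyl in place of (2-(4-chlorophenyl)ethenyl)carbonyl on an aromatic carbon. The carbonyl and the double bond swap ends, and the chlorine on the outer ring is gone. Neither measured step covers this swap; the nearest is the step from compound 2 to compound 3, which only exchanged one group on that outer ring and moved the number by nothing beyond the scatter. For the measured compounds named here, with no step bearing directly on the swap, the expectation for compound 4 is a step of a 1.0-fold higher number from compound 1 to compound 4 (0.01 log units; within the scatter) in this assay, that is, no change beyond the scatter, with wide uncertainty. Compound 4 is therefore estimated at 22000 nM, within 7000 nM to 70000 nM.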

Compound 4, half-maximal inhibitory concentration: 15800 nM
Compound 4: middle estimate off by 1.4-fold (0.14 log units), on the high side; measured number inside the range.
By their numbers in this assay, from the lowest: compounds 4, 1, 3 and 2 (each within the scatter of the next).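

Until now, every step concerned a group on an outer ring, leaving the linker between the shared core and the outer ring untested. In this assay, placing 2-benzoylethenyl where (2-(4-chlorophenyl)ethenyl)carbonyl stood gives a 1.4-fold lower number from compound 1 to compound 4 (0.14 log units; within the scatter), so at this position the linker can run the other way round, even with the chlorine gone, without a shift that can be told from the scatter. No supporting measurement is available to explain this outcome.

The reversed linker and the lost chlorine arrive together here, so a reversed linker that keeps the chlorine on its outer ring would be needed to separate the two changes. Also open, as far as these compounds go, is how this position responds to a linker without the enone, such as an amide or a saturated carbon chain ending in an amine.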